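The compounds below may be only part of what the source reports. "The series", "measured", "known", "first", "only" and "open" are said of these compounds alone.

Working notes on the urea series in an ADME assay on the whole organism with Oryza sativa as the target, tested at 1 uM; on this read-out lower numbers stand for a stronger effect and higher numbers for a weaker effect at the one concentration tested.

Of the compounds shown here, three carry numbers so far. Compound 1 `Cc1ccccc1NC(=O)N[C@H](C)c1ccccc1` gives 100% in this assay, and compound 3 `CC(=O)c1ccc(NC(=O)N[C@H](C)c2ccccc2)cc1` gives 93%. Compound 2 `Cc1ccccc1NC(=O)N[C@@H](C)c1ccccc1` gives 99%. Compound 2 thus sits among three close numbers: its value and that of compound 1 lie within the scatter of each other, as do its value and that of compound 3, so no order among the three can be read from this assay.

Within the data shown here, the one measured step that differs in a single place is a number 1 percentage points lower from compound 1 to compound 2 (within the scatter); it rests on the fact that compounds 1 and 2 differ only in the configuration as drawn and concerns the drawn configuration only. Compound 3 differs from compound 2 in more than one place, so its value shows only that this assay has so far returned uniformly weak effects.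

The next compound, compound 4 `C[C@H](NC(=O)Nc1ccccc1Br)c1ccccc1`, changes bromo in place of methyl on an aromatic carbon relative to compound 2. Among the measured compounds shown here, no measured step bears on a change of this kind: the stereo inversion from compound 1 to compound 2 says nothing about a substituent swap on the aromatic ring, and no other single-point step exists. With all three measured numbers close to the top of the scale, the expectation for compound 4 is a step of a number 4 percentage points lower from compound 2 to compound 4 (within the scatter) that stays within the scatter. Compound 4 is therefore estimated at 95%, with a range from 82% to 100%.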

Compound 4, a percentage reported as activity, at one concentration (the size of the read-out at that concentration, not a potency): 99%
For compound 4 the middle estimate is 4 percentage points below the measured one; the measured number falls inside the stated range.
By their numbers in this assay, from the lowest: compounds 3, 2, 4 and 1 (each within the scatter of the next).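

In this assay, bromo in place of methyl on an aromatic carbon, ortho to a large group, gives no change at the digits printed from compound 2 to compound 4 (within the scatter). Among these compounds, this is the first single-place step that concerns a substituent rather than the drawn configuration, and it does not separate the two compounds: one heavy atom replaces another, with the counted hydrogen-bond donors and acceptors unchanged on both sides, and the number stays close to the top of the scale. Nothing available bears on why this exchange leaves the two compounds inseparable in this read-out, and the single point supports no statement about the properties of either group.

Among the compounds shown here, whether a group of a different kind at this place, such as an amine, a carboxylic acid or a longer chain, would stand apart from compound 2 remains open, since methyl and bromo are the only two groups compared here. Also open, going by these compounds, is whether any change to the shared core can move the read-out beyond the scatter, as the four compounds so far lie each within the scatter of the next.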